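The source may hold more compounds than are shown below. What is called first, only, known or untested is meant among the compounds shown, and "the series" means these compounds.

In a functional assay on NCI-H226 cells (Homo sapiens) for inhibition, read by MTT assay, with a stated time of 72 h (on this read-out lower numbers stand for stronger inhibition of growth and higher numbers for weaker inhibition of growth), compound 3 `CCc1nc(C(=O)OC)nn1-c1ccc(F)cc1` gives 71300 nM. Compound 2 `COC(=O)c1nc(C)n(-c2ccc(Cl)cc2)n1` gives 84000 nM in this assay. Compound 1 `COC(=O)c1nc(C)n(-c2ccccc2)n1` reaches only the assay limit in this assay, > 100000 nM; that is the limit of > 100000 nM in this assay, at which 1 of the 3 values shown sits. Compound 3 therefore holds the lowest of the two numbers shown, its nearest neighbour being compound 2, whose value sits within the scatter of it, so no order between compound 3 and compound 2 is claimed. For the measured compounds named here, the single measured step, an at least 1.1-fold lower number from compound 1 to compound 2 (0.07 log units; that floor lies within the scatter), starts from a limit and stays within the scatter. Compound 4 `COC(=O)c1nc(-c2ccsc2)n(-c2ccc(F)cc2)n1` differs from compound 3 by thiophen-3-yl in place of ethyl on an aromatic carbon. Going by the values given here, no measured step touches that position or that kind of exchange, and the one step available shows nothing beyond the scatter. The expected step is thus a 1.4-fold lower number from compound 3 to compound 4 (0.15 log units; within the scatter) in this assay, held to about the size the scatter allows. Compound 4 is expected to give 50000 nM in this assay. The expected range for compound 4 runs from 15000 nM to 150000 nM, with a fair chance that only a limit is reported.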

Compound 4, concentration for 50% growth inhibition: 6940 nM
Beside the measured number, compound 4's estimate is 7.2-fold (0.86 log units) above it, outside the stated range (below it).
By their numbers in this assay, from the lowest: compound 4; then compounds 3 and 2 (each within the scatter of the next). At a limit, above all of these: compound 1.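

For the compounds shown here, the aromatic carbon between two ring nitrogen atoms, which carries methyl or ethyl in the earlier compounds, is the first place where one exchange moves the number beyond the scatter: thiophen-3-yl in place of ethyl gives a 10-fold lower number from compound 3 to compound 4 (1.01 log units; beyond the scatter) in this assay. Going by these compounds alone, the position therefore accepts an aromatic ring and responds to it, whereas the only earlier step, chloro in place of hydrogen, showed nothing beyond the scatter. No measurement shown speaks to the reason for this step.

As far as these compounds go, a single exchange does not separate the thiophen-3-yl ring from the added heavy atoms, and phenyl, a longer chain such as butyl, or an amine at this carbon remains open. From the compounds shown here alone, whether the step holds with a carboxylic acid in place of the methoxycarbonyl group also remains open.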